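Biaryl amide series against breast cancer cells: weak inhibitors

The source may report more compounds than this note shows. Statements on the series, on what has been measured and on what is new or still open speak of the compounds shown alone.

The shared core of compound 1 `O=C(Nc1ccc(Oc2ccnc3[nH]ccc23)c(F)c1)c1cc(-c2ccccc2)ccn1` carries a phenyl group, and in a functional assay on MCF7 cells (Homo sapiens) for cytotoxicity, read by MTT assay, with a stated time of 72 h (a higher number here means a weaker inhibitor, a lower number a stronger inhibitor), compound 1 gives only a limit of the assay, > 10000 nM. Compound 2 `Cc1ccc(-c2ccnc(C(=O)Nc3ccc(Oc4ccnc5[nH]ccc45)c(F)c3)c2)cc1` gives 8430 nM in this assay, and compound 3 `Cc1ccc(-c2ccnc(C(=O)Nc3ccc(Oc4ccnc5[nH]ccc45)c(F)c3)c2)c(C)c1` gives 6220 nM. Compound 3 has the lowest of the two numbers, but the steps of a 1.4-fold lower number from compound 2 to compound 3 (0.13 log units; within the scatter) and an at least 1.6-fold lower number from compound 1 to compound 3 (0.20 log units; that floor lies within the scatter) stay within the scatter, as does an at least 1.1-fold lower number from compound 1 to compound 2 (0.07 log units; that floor lies within the scatter), so no order among these three is established. Compound 4 `CCc1ccc(-c2ccnc(C(=O)Nc3ccc(Oc4ccnc5[nH]ccc45)c(F)c3)c2)cc1` differs from compound 3 in one place: 4-ethylphenyl in place of 2,4-dimethylphenyl on an aromatic carbon. The two methyl steps measured here were small, so the expected step of a 1.1-fold higher number from compound 3 to compound 4 (0.05 log units; within the scatter) should not exceed the scatter. Compound 4 is therefore estimated at 7000 nM, between 3000 nM and 20000 nM.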

Compound 4, half-maximal inhibitory concentration: 7470 nM
Compound 4: the middle estimate sits 1.1-fold (0.03 log units) below what was measured; the measured number falls inside the stated range.
By their numbers in this assay, from the lowest: compounds 3, 4 and 2 (each within the scatter of the next). At a limit, above all of these: compound 1.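

With the same atoms joined differently, 4-ethylphenyl in place of 2,4-dimethylphenyl opposite the ring nitrogen gives a 1.2-fold higher number from compound 3 to compound 4 (0.08 log units; within the scatter), so this rearrangement does not separate the two compounds. Methyl in place of hydrogen on the chain carbon gives a 1.1-fold lower number from compound 2 to compound 4 (0.05 log units; within the scatter), so ethyl and methyl are not separated here either. Ethyl in place of hydrogen gives an at least 1.3-fold lower number from compound 1 to compound 4 (0.12 log units; that floor lies within the scatter), and that step is only a floor, because compound 1 stands at a limit: the limit of > 10000 nM in this assay, at which 1 of the 4 values shown sits.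

As far as these compounds go, it remains open whether an amine, a carboxylic acid or a longer chain at this position would give a step beyond the scatter in this assay.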